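The source may hold more compounds than are shown below. What is called first, only, known or untested is meant among the compounds shown, and "the series" means these compounds.

Compound 1 `CCCCc1ccc(-c2cc3cn([C@H]4C[C@H](O)[C@@H](CO)O4)c(=O)nc3s2)cc1` and compound 2 `CCCCCCc1ccc(-c2cc3cn([C@H]4C[C@H](O)[C@@H](CO)O4)c(=O)nc3s2)cc1` share one core and differ only in the length of a chain. In a functional assay on HeLa cells (Homo sapiens) for cytotoxicity (a higher number here means that more compound is tolerated, a lower number that less compound is tolerated), compound 1 gives only a limit of the assay, > 200000 nM. In this assay compound 2 likewise gives only a limit, > 200000 nM. The step that the two limits leave unreadable from compound 1 to compound 2 therefore cannot be sized, and the limit of > 200000 nM in this assay, at which 2 of the 2 values shown sit, leaves both compounds at the same ceiling. Compound 3 `CCCCCc1ccc(-c2cc3cn([C@H]4C[C@H](O)[C@@H](CO)O4)c(=O)nc3s2)cc1` differs from compound 2 by hydrogen in place of methyl on a saturated chain carbon, five bonds along the chain from an aromatic carbon. With no readable step to lean on, compound 3 is expected to reach the same limit, estimated at 200000 nM within a range of 100000 nM to 400000 nM. The expected step is a number no higher from compound 2 to compound 3 (the limit leaves the size open).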

Compound 3, half-maximal cytotoxic concentration: > 200000 nM
Compound 3: only a limit was reported; the forecaster's own chance of this, stated with the estimate: 85%; the middle value lies on the limit itself.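

Within the data shown here, no step among compound 1, compound 2 and compound 3 can be read, as all three stand at one limit: the limit of > 200000 nM in this assay, at which 3 of the 3 values shown sit. Where the half-maximal cytotoxic concentration of each compound actually lies, and whether chain length changes it, stays open.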